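Replacing benzyl with a sulfonyl group on the shared core

The source may hold more compounds than are shown below. What is called first, only, known or untested is meant among the compounds shown, and "the series" means these compounds.

Measured in a functional assay on MDA-MB-231 cells (Homo sapiens) for antiproliferative activity, read by MTT assay, with a stated time of 72 h (a higher number here means a weaker inhibitor, a lower number a stronger inhibitor), so far
compound 1 `CC1=CC[C@H]2[C@H](CC[C@]2(C)O)C(C)(C)[C@@H]1CC[C@H]1[C@]2(C)CC[C@H](OC(=O)c3ccc(Cl)cc3)C(C)(C)O[C@H]2CC[C@@]1(C)O` gives 10300 nM
compound 2 `CC1=CC[C@H]2[C@H](CC[C@]2(C)O)C(C)(C)[C@@H]1CC[C@H]1[C@]2(C)CC[C@H](OC(=O)NCc3ccccc3)C(C)(C)O[C@H]2CC[C@@]1(C)O` gives 40300 nM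

In this assay compound 2 has the higher number of the pair, at 40300 nM, and is therefore the weaker inhibitor. The next change gives compound 3 `CC1=CC[C@H]2[C@H](CC[C@]2(C)O)C(C)(C)[C@@H]1CC[C@H]1[C@]2(C)CC[C@H](OC(=O)NS(=O)(=O)c3ccc(C)cc3)C(C)(C)O[C@H]2CC[C@@]1(C)O` and reads ((4-methylphenyl)sulfonyl in place of benzyl on an amide-type nitrogen), that is, (4-methylphenyl)sulfonyl in place of benzyl on an amide-type nitrogen. For the measured compounds named here, only one measured step bears on this: a 3.9-fold higher number from compound 1 to compound 2 (0.59 log units; beyond the scatter), a modest change beyond the scatter, made at the group on the carbonyl carbon. Going by the values given here, no measured compound carries a sulfonyl group, so the direction is weakly supported. A modest step towards a lower number is tentatively expected, in the size range of that single step. The expected move is a 2.0-fold lower number from compound 2 to compound 3 (0.30 log units; within the scatter) in this estimate. For compound 3 the estimated value is 20000 nM, with an expected range of 7000 nM to 50000 nM in this estimate.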

Compound 3, half-maximal inhibitory concentration: 47100 nM
The estimate for compound 3 lay 2.4-fold (0.37 log units) below the measured number; low and high end bracket the measured number.
By their numbers in this assay, from the lowest: compound 1; then compounds 2 and 3 (each within the scatter of the next).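

In this assay, (4-methylphenyl)sulfonyl in place of benzyl on the amide-type nitrogen gives a 1.2-fold higher number from compound 2 to compound 3 (0.07 log units; within the scatter), so exchanging these two groups, both carrying an aromatic ring, leaves no readable difference at this position. Measured against compound 1, ((4-methylphenyl)sulfonyl)amino in place of 4-chlorophenyl on the carbonyl carbon gives a 4.6-fold higher number from compound 1 to compound 3 (0.66 log units; beyond the scatter), which places compound 3 as well as compound 2 at higher numbers than compound 1, with neither of these two compounds going against that pattern. Nothing measured on these compounds explains the numbers.

Still open, as far as these compounds go, is whether a methylsulfonyl or acetyl group on the amide-type nitrogen would read differently from compound 3. From the compounds shown here alone, it is also open whether any group attached through this nitrogen, such as a longer alkyl chain, can reach the level of compound 1.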